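The source may report more compounds than this note shows. Statements on the series, on what has been measured and on what is new or still open speak of the compounds shown alone.

Working notes on the ester series.

Compound 1 `CC1=CC[C@H](C(C)C)c2cc(C)c(OC(=O)c3ccc([N+](=O)[O-])cc3)cc21` gives 67.8% in a functional assay on HCT-15 cells (Homo sapiens) for antiproliferative activity, read by sulforhodamine B assay, with a stated time of 48 h, tested at 50 uM; on this read-out lower numbers stand for less inhibition and higher numbers for more inhibition at the one concentration tested (going by the name of the read-out). Compound 2 `COc1ccc(C(=O)Oc2cc3c(C)ccc(C(C)C)c3cc2C)cc1` gives 84% in this assay. Of the two numbers in hand, compound 1 is the lower one, and the gap to compound 2 is beyond the usual scatter of this kind of measurement. Within the data shown here, the two compounds differ in more than one place, so no single-change step between measured compounds is available to lean on.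

Compound 3 `CC1=CC[C@H](C(C)C)c2cc(C)c(OC(=O)c3cccc(C)c3)cc21` has not yet been measured in this assay. Relative to compound 1 the change is 3-methylphenyl in place of 4-nitrophenyl on a carbonyl carbon.

Among the measured compounds shown here, with no measured step of this kind to go by, the expectation rests only on the value of compound 1, which gives 67.8%, and on the fact that the core of compound 1 is kept unchanged. The step from compound 1 to compound 3 is estimated as a number 2.2 percentage points higher from compound 1 to compound 3 (within the scatter), that is, a small move in either direction that need not exceed the scatter. For compound 3 the estimated value in this assay is 70%, with a range from 50% to 88%.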

Compound 3, a percentage reported as inhibition, at one concentration (the size of the read-out at that concentration, not a potency): 5.3%
Compound 3: middle estimate off by 64.7 percentage points, on the high side; measured number outside the range, below it.
By their numbers in this assay, from the lowest: compound 3; then compound 1; then compound 2.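

In this assay, the aryl group on the carbonyl carbon is shown to matter on its own: with the core of compound 1 kept, 3-methylphenyl in place of 4-nitrophenyl gives a number 62.5 percentage points lower from compound 1 to compound 3 (beyond the scatter). The gap between the two earlier compounds could not be tied to any one place, whereas this single change takes the read-out down to 5.3% for compound 3, so this position alone can separate a compound with substantial inhibition from one with little. Nothing measured on these compounds accounts for the size of this step.

As far as these compounds go, this one step cannot tell whether the outcome follows from the departure of the 4-nitrophenyl group or from the arrival of the 3-methylphenyl group, and how a plain phenyl ring, or an aryl ring carrying an amine or a carboxylic acid, would read at this position remains open. Also open, from the compounds shown here alone, is whether a step of this size would recur on the core of compound 2, since the shared core of compound 1 and compound 3 is the only setting in which this change has a reading.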